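Swapping an aminomethyl for an ethynyl on the side chain

This account rests on a few compounds, and the source may have more. Where it says the series, first, only, none or still open, it means among the compounds named here.

Measured so far:
- compound 1, `C=CCN(Cc1ccc2nc(C)[nH]c(=O)c2c1)c1ccc(C(=O)N[C@@H](CCC(=O)O)C(=O)O)cc1`: 480 nM
- compound 2, `Cc1nc2ccc(CN(CCN)c3ccc(C(=O)N[C@@H](CCC(=O)O)C(=O)O)c(F)c3)cc2c(=O)[nH]1`: 11700 nM

In an assay on isolated protein for inhibition of Thymidylate synthase (Mus musculus) (a higher number here means a weaker inhibitor, a lower number a stronger inhibitor), compound 2 stands highest of the two numbers, and compound 1 has a number that is lower by a margin well beyond the usual scatter. Compound 3, `C#CCN(Cc1ccc2nc(C)[nH]c(=O)c2c1)c1ccc(C(=O)N[C@@H](CCC(=O)O)C(=O)O)c(F)c1`, is not yet measured. It differs from compound 2 in one place: ethynyl in place of aminomethyl on a saturated chain carbon bound to a nitrogen on an aromatic ring. Compound 1 also carries a short chain without an amine on that nitrogen, and in this assay compound 1 gives 480 nM, so a large step downward, toward a stronger inhibitor, is expected here; the step from a 78-fold lower number from compound 2 to compound 3 (1.89 log units; beyond the scatter) is the estimated size of that drop. Among the compounds with values here, with the fluorine retained from compound 2 and no directly comparable pair available, the expectation for compound 3 is 150 nM, within a range from 30 nM to 800 nM.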

Compound 3, half-maximal inhibitory concentration: 20 nM
Compound 3: middle estimate off by 7.5-fold (0.88 log units), on the high side, and the stated range ends above it.
By their numbers in this assay, from the lowest: compound 3; then compound 1; then compound 2.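

In this assay the change from 2-aminoethyl to propargyl on this nitrogen gives a 590-fold lower number from compound 2 to compound 3 (2.77 log units; beyond the scatter) and so shows that, with the fluorine kept in place, this position responds strongly to what it carries. The step is large even though 2 heavy atoms leave and 2 enter, so the size of the group alone, counted this way, does not set the outcome here. The ethynyl brings no hydrogen-bond donor or acceptor where the aminomethyl brought one of each, but no measurement shown explains the size of the step.

A propyl or 2-hydroxyethyl chain on the same nitrogen would help show whether the gain follows from adding the ethynyl or from losing the amine. Compound 1 differs from compound 3 in two places, so it cannot separate the effect of the triple bond from that of the fluorine.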